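Removal of a phenolic hydroxy in a small cytotoxicity series

The source may report more compounds than this note shows. Statements on the series, on what has been measured and on what is new or still open speak of the compounds shown alone.

Measured so far:
compound 1 `COc1ccc(/C=C/C(=O)c2ccc(OC)c(OC)c2)cc1O` — 73.5%
compound 2 `COc1ccc(C(=O)CCc2ccc(OC)cc2OC)c(O)c1` — 83.4%

In an ADME assay on RAW264.7 cells (Mus musculus) for cytotoxicity, read by MTT assay, with a stated time of 24 h, tested at 10 ug/mL (on this read-out higher numbers stand for a weaker effect at the one concentration tested and lower numbers for a stronger effect), compound 1 gives 73.5% and compound 2 gives 83.4%. Compound 1 has the smaller of the two numbers, yet the gap to compound 2 lies within the scatter, so the two compounds are not told apart on this read-out. Going by the values given here, no pair of measured compounds differs in one place only, so no single-change step has been measured here.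

Compound 3 `COc1ccc(/C=C/C(=O)c2ccc(OC)c(OC)c2)cc1` is the next compound for this assay. It differs from compound 1 as follows: hydrogen in place of hydroxy on an aromatic carbon. The ring in question thus keeps its methoxy group and loses only the hydroxy.

Among the compounds with values here, with only two measured numbers, which do not separate, there is no basis for expecting a step beyond the scatter in this assay. The step from compound 1 is therefore expected to be small, a number 1.5 percentage points higher from compound 1 to compound 3 (within the scatter), in no firm direction. Compound 3 is accordingly expected to give about 75%, within a range of 60% to 90%.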

Compound 3, a percentage reported as activity, at one concentration (the size of the read-out at that concentration, not a potency): 73.9%
The estimate for compound 3 lay 1.1 percentage points above the measured number, and the stated range covers the measured number.
By their numbers in this assay, from the lowest: compounds 1, 3 and 2 (each within the scatter of the next).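

In this assay, going by these compounds alone, the replacement of hydroxy by hydrogen on an aromatic carbon, ortho to a methoxy group, gives the first single-change step, a number 0.4 percentage points higher from compound 1 to compound 3 (within the scatter), and so the two compounds are not told apart. At this position, then, removing the hydroxy, with its one hydrogen-bond donor and one hydrogen-bond acceptor, leaves no effect that can be read at the one concentration tested, while the methoxy group and the rest of the core of compound 1 stay unchanged. Nothing at hand accounts for this outcome.

Still open, on these data alone, is whether an amine, a carboxylic acid or a longer alkoxy chain in this same place would also stay within the scatter, or whether this position tolerates only small changes such as the one seen here. Also open, as far as these compounds go, is whether the same replacement would give a similar result on a different core, and a read-out at one concentration cannot show whether potency differs between compound 1 and compound 3.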